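Changing the sulfur substituent at low growth inhibition

The compounds below may be only part of what the source reports. "The series", "measured", "known", "first", "only" and "open" are said of these compounds alone.

In a functional assay on A-375 cells (Homo sapiens) for inhibition, read by CCK-8 assay, with a stated time of 72 h, tested at 2 uM (on this read-out higher numbers stand for more inhibition of growth at the one concentration tested and lower numbers for less inhibition of growth), compound 1 `Nc1ccccc1NC(=O)/C=C/c1ccc(CSc2ccc(Cl)cc2)cc1` gives 13.4%, compound 2 `CCc1ccc(SCc2ccc(/C=C/C(=O)Nc3ccccc3N)cc2)cc1` gives 5.27% and compound 3 `Nc1ccccc1NC(=O)/C=C/c1ccc(CSc2ccc(C(F)(F)F)cn2)cc1` gives 10.3%. These three numbers cannot be told apart, so compound 3 stands within the scatter of both of the others. Its two measured steps are a number 3.1 percentage points lower from compound 1 to compound 3 (within the scatter) and a number 5 percentage points higher from compound 2 to compound 3 (within the scatter).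

The next compound is compound 4 `Nc1ccccc1NC(=O)/C=C/c1ccc(CSc2ccc(F)cc2)cc1`. The change is 4-fluorophenyl in place of 5-(trifluoromethyl)pyridin-2-yl on a sulfur, which puts 4-fluorophenyl in place of 5-(trifluoromethyl)pyridin-2-yl on a sulfur. The group on this same sulfur has already been varied, and those steps bear directly on the question. The relevant evidence is a number 3.1 percentage points lower from compound 1 to compound 3 (within the scatter), a number 5 percentage points higher from compound 2 to compound 3 (within the scatter) and also a number 8.1 percentage points lower from compound 1 to compound 2 (within the scatter), and none of them leaves the scatter. No step beyond the scatter is therefore expected in this assay, in either direction. The expected step is a number 0.3 percentage points lower from compound 3 to compound 4 (within the scatter). Compound 4 is estimated at 10%, with an expected range from 2% to 20%.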

Compound 4, percent growth inhibition at one concentration: 28.8%
Compound 4: the middle estimate sits 18.8 percentage points below what was measured; the measured number lies above the stated range.
By their numbers in this assay, from the lowest: compounds 2, 3 and 1 (each within the scatter of the next); then compound 4.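

In this assay, the group on this sulfur can shift the result beyond the scatter, which no earlier change had done: 4-fluorophenyl in place of 5-(trifluoromethyl)pyridin-2-yl gives a number 18.5 percentage points higher from compound 3 to compound 4 (beyond the scatter). On the aromatic carbon, fluoro in place of ethyl gives a number 23.5 percentage points higher from compound 2 to compound 4 (beyond the scatter), and fluoro in place of chloro gives a number 15.4 percentage points higher from compound 1 to compound 4 (beyond the scatter), so compound 4 stands apart from all three earlier compounds, though the effect remains modest. Nothing available here accounts for the fluoro compound standing apart.

As far as these compounds go, whether fluoro is special on that aromatic carbon remains open, since plain hydrogen, a methoxy group, an amine or a carboxylic acid there would be needed for comparison. These single-concentration numbers also leave open how compound 4 would behave across a range of concentrations.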